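The source may hold more compounds than are shown below. What is called first, only, known or untested is meant among the compounds shown, and "the series" means these compounds.

Working notes on the series.

Of the compounds shown here, two have numbers so far. Compound 1 `N#CCC1=NN=C(c2ccc(Br)cc2)C(Br)O1` carries a bromo group on its aromatic ring; in a functional assay on SF-268 cells (Homo sapiens) for inhibition, read by sulforhodamine B assay, with a stated time of 48 h (on this read-out lower numbers stand for stronger inhibition of growth and higher numbers for weaker inhibition of growth), compound 1 gives 32000 nM. Compound 2 `N#CCC1=C(C#N)CC(c2ccc([N+](=O)[O-])cc2)=C(CC(=O)c2ccc(Br)cc2)O1` is built on a different core and, in this assay, compound 2 gives 2800 nM, the lower of the two numbers, with compound 1 standing at a gap beyond the scatter above it. The two compounds share no single point of difference, so their two values show only this gap and nothing more.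

Compound 3 `N#CCC1=C(C#N)CC(c2ccc([N+](=O)[O-])cc2)=C(CC(=O)c2ccc([N+](=O)[O-])cc2)O1` has not been measured. It differs from compound 2 in one place: nitro in place of bromo on an aromatic carbon, on an aromatic carbon of a six-membered aromatic ring of carbon only. Among the compounds with values here, no measured pair shows such an exchange, so the step has no precedent here. The expectation is a step within the scatter, a 1.1-fold higher number from compound 2 to compound 3 (0.03 log units; within the scatter), in either direction. Compound 3 in this assay is estimated at 3000 nM, within a range from 1200 nM to 8000 nM.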

Compound 3, concentration for 50% growth inhibition: 5 nM
Estimate against measurement, compound 3: 600-fold (2.78 log units) above; the whole stated range lies above it.
By their numbers in this assay, from the lowest: compound 3; then compound 2; then compound 1.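

Within the data shown here, the exchange of 4-bromophenyl for 4-nitrophenyl is the first change confined to one place, and in this assay it gives a 560-fold lower number from compound 2 to compound 3 (2.75 log units; beyond the scatter). The rest of the structure is the same in both compounds, so this position on the aromatic ring, para to a large group, is shown to be far from indifferent to the group it carries. No measurement on hand bears on why the step is so large.

From the compounds shown here alone, it remains open whether the low number is particular to nitro or would also appear with an amine, a carboxylic acid or a methoxy group at this position. Also open, going by these compounds, is how much the step depends on the second nitro group, the one on the other aromatic ring of both compounds.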